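Aryl sulfonate esters on two related cores: cytotoxicity notes

The source may report more compounds than this note shows. Statements on the series, on what has been measured and on what is new or still open speak of the compounds shown alone.

Measured so far in a functional assay on SW480 cells (Homo sapiens) for cytotoxicity, read by MTT assay, with a stated time of 4 days; a lower number here means a stronger inhibitor, a higher number a weaker inhibitor:
compound 1 `Cc1ccc(S(=O)(=O)Oc2ccc3c(c2C)[C@H](Cn2cc(-c4ccccn4)nn2)[C@@]24CC(=O)[C@@](C)(CC[C@@H]32)C4)cc1`: > 20000 nM, a limit of the assay.
compound 2 `Cc1c(O)ccc2c1[C@H](Cn1cc(-c3ccccn3)nn1)[C@@]13CC(=O)[C@@](C)(CC[C@@H]21)C3`: > 20000 nM, also a limit of the assay.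
compound 3 `C=C1C(=O)[C@]23C[C@@]1(O)CC[C@H]2c1ccc(O)c(C)c1[C@@H]3Cn1cc(-c2ccc(F)cc2)nn1`: 250 nM.

Compound 1 and compound 2 differ by (4-methylphenyl)sulfonyl in place of hydrogen on an oxygen on an aromatic ring. With both values at the limit, the step that the two limits leave unreadable from compound 2 to compound 1 cannot be sized; all that can be said of it is the limit of > 20000 nM in this assay, at which 2 of the 3 values shown sit. How the core of compound 3 differs from the core of compound 2 is not broken down here.

Compound 4 `C=C1C(=O)[C@]23C[C@@]1(O)CC[C@H]2c1ccc(OS(=O)(=O)c2ccc(C)cc2)c(C)c1[C@@H]3Cn1cc(-c2ccc(F)cc2)nn1` carries the same change on the core of compound 3, namely ((4-methylphenyl)sulfonyl in place of hydrogen on an oxygen on an aromatic ring). The earlier pair gives no readable size for this change, so the expectation for compound 4 rests on compound 3 alone, at 250 nM in this assay. The step of a 2.4-fold higher number from compound 3 to compound 4 (0.38 log units; beyond the scatter) is expected to be modest. Compound 4 is therefore estimated at 600 nM in this assay, with a wide range.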

Compound 4, half-maximal inhibitory concentration: 1630 nM
Estimate against measurement, compound 4: 2.7-fold (0.43 log units) below, within the range that was stated.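

In this assay, (4-methylphenyl)sulfonyl in place of hydrogen on an oxygen on an aromatic ring gives a 6.5-fold higher number from compound 3 to compound 4 (0.81 log units; beyond the scatter), the only readable size for this change in the series. On the core of compound 2, the same change cannot be read, as compound 1 and compound 2 both sit at a limit of the assay: the limit of > 20000 nM in this assay, at which 2 of the 4 values shown sit. The series thus shows a weaker compound on one core, but not whether the step carries over to another core, since a single readable pair offers nothing to compare it with.

Open, going by these compounds, is whether a methyl ether on that oxygen, or an amine or a carboxylic acid on the ring of the sulfonyl group, would give a step of similar size on the core of compound 3. Also open, on these data alone, is whether any such group would bring the core of compound 2 to a readable value.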